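Thiophene for methoxyphenyl on the thiophene core

The compounds below may be only part of what the source reports. "The series", "measured", "known", "first", "only" and "open" are said of these compounds alone.

Measured so far in an assay on microsomes for inhibition of 3-hydroxy-3-methylglutaryl-coenzyme A reductase (Rattus norvegicus); on this read-out higher numbers stand for weaker inhibition and lower numbers for stronger inhibition:
Compound 1 `CC(C)c1sc(-c2ccccc2)c(C2CCCC2)c1/C=C/[C@@H](O)C[C@@H](O)CC(=O)O` gives 417 nM.
Compound 2 `CC(C)c1sc(-c2ccccc2)c(-c2ccccc2F)c1/C=C/[C@@H](O)C[C@@H](O)CC(=O)O` gives 233 nM.
Compound 3 `COc1ccc(-c2c(-c3ccccc3)sc(C(C)C)c2/C=C/[C@@H](O)C[C@@H](O)CC(=O)O)cc1` gives 2430 nM.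

Among these three, compound 3 shows the highest number and therefore the weakest inhibition: compound 1 sits a 5.8-fold higher number from compound 1 to compound 3 (0.77 log units; beyond the scatter) away, and compound 2 further, a 10-fold higher number from compound 2 to compound 3 (1.02 log units; beyond the scatter).

Compound 4 `CC(C)c1sc(-c2ccccc2)c(-c2cccs2)c1/C=C/[C@@H](O)C[C@@H](O)CC(=O)O` has not yet been measured. Its difference from compound 3 is thiophen-2-yl in place of 4-methoxyphenyl on an aromatic carbon. The two steps that bear on this position both end at compound 3, with 4-methoxyphenyl entering: a 5.8-fold higher number from compound 1 to compound 3 (0.77 log units; beyond the scatter) and a 10-fold higher number from compound 2 to compound 3 (1.02 log units; beyond the scatter). Both show that the 4-methoxyphenyl group at this carbon goes with a clearly higher number than cyclopentyl or 2-fluorophenyl. Thiophen-2-yl is a further aromatic ring at the same place, of five heavy atoms rather than eight, and no other measured compound carries it. Removing the 4-methoxyphenyl is therefore expected to bring the number back down, roughly toward where compounds 1 and 2 lie, so the step of a 6.1-fold lower number from compound 3 to compound 4 (0.78 log units; beyond the scatter) is expected to be a modest fall. For compound 4 in this assay the estimate is 400 nM, between 150 nM and 1100 nM.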

Compound 4, half-maximal inhibitory concentration: 1420 nM
Compound 4: middle estimate off by 3.6-fold (0.55 log units), on the low side; measured number outside the range, above it.
By their numbers in this assay, from the lowest: compounds 2 and 1 (each within the scatter of the next); then compounds 4 and 3 (each within the scatter of the next).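

In this assay, removing the 4-methoxyphenyl does not by itself restore the lower numbers: thiophen-2-yl gives a 1.7-fold lower number from compound 3 to compound 4 (0.23 log units; within the scatter) and so cannot be told apart from 4-methoxyphenyl here, even though it has fewer heavy atoms. It does stand clearly apart from the other two groups at this carbon, with a 6.1-fold higher number from compound 2 to compound 4 (0.78 log units; beyond the scatter) and a 3.4-fold higher number from compound 1 to compound 4 (0.53 log units; beyond the scatter) and so the lower numbers go with 2-fluorophenyl and cyclopentyl, while an aromatic ring as such does not guarantee them, as compounds 3 and 4 show. No measurement at hand explains this difference between the groups.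

The compounds shown leave open whether a plain phenyl ring at this carbon would sit with compound 2 or with compound 4. They also leave open how a cyclohexyl ring would compare with the cyclopentyl of compound 1.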